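This account rests on a few compounds, and the source may have more. Where it says the series, first, only, none or still open, it means among the compounds named here.

Measured so far in a toxicity assay on WI-38 cells (Homo sapiens) for inhibition, read by MTT assay, with a stated time of 72 h; a higher number here means a weaker inhibitor, a lower number a stronger inhibitor:
- Compound 1 `O=C(NCc1ccc(NC(=O)c2cc(F)ccc2N2CCCC2)cc1)OCc1cccnc1`: > 100000 nM (a limit)
- Compound 2 `COc1ccc(N2CCCC2)c(C(=O)Nc2ccc(CNC(=O)OCc3cccnc3)cc2)c1`: 35600 nM
- Compound 3 `O=C(NCc1ccc(NC(=O)c2cc(Cl)ccc2N2CCCC2)cc1)OCc1cccnc1`: > 100000 nM (a limit)

Compound 3 gives > 100000 nM in this assay, and this is a limit of the assay rather than a number. Compound 3 therefore shares with compound 1 (the limit of > 100000 nM in this assay, at which 2 of the 3 values shown sit).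

Compound 4 `O=C(NCc1ccc(NC(=O)c2cc(C(F)(F)F)ccc2N2CCCC2)cc1)OCc1cccnc1` carries trifluoromethyl in place of chloro on an aromatic carbon, para to a pyrrolidin-1-yl group: trifluoromethyl in place of chloro on an aromatic carbon.

Within the data shown here, no measured step makes this exact exchange, but three measured steps change the same place. Methoxy in place of fluoro gave an at least 2.8-fold lower number from compound 1 to compound 2 (0.44 log units; beyond the scatter). Chloro in place of methoxy gave an at least 2.8-fold higher number from compound 2 to compound 3 (0.44 log units; beyond the scatter). Chloro in place of fluoro gave a step that the two limits leave unreadable from compound 1 to compound 3. Only compound 2, the methoxy member, gives a true number, and compound 4 does not carry methoxy. With fluoro in compound 1 and chloro in compound 3 both resting at the limit of > 100000 nM in this assay, at which 2 of the 3 values shown sit, no clear step is expected in this assay, and the assay may well report only a limit again. The estimated step is an at least 1.1-fold lower number from compound 3 to compound 4 (0.04 log units; that floor lies within the scatter). The expected value for compound 4 is 90000 nM, with an estimated range from 35000 nM to 130000 nM.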

Compound 4, half-maximal inhibitory concentration: > 100000 nM
Compound 4 ended at the assay's limit; the forecaster's own chance of this, stated with the estimate: 60%; at least 1.1-fold (0.04 log units) between middle value and limit.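

The new member widens the picture at this position on the aromatic carbon, para to a pyrrolidin-1-yl group: trifluoromethyl, with more heavy atoms than chloro, still yields no true number in this assay. Among these compounds, the one step that can be read is an at least 2.8-fold higher number from compound 2 to compound 4 (0.44 log units; beyond the scatter), so the methoxy member now stands apart from three other groups at this place rather than two, which makes it a single exception and not one end of a graded series. The steps among compound 1, compound 3 and compound 4 cannot be read, since all three rest on the same limit of the assay, which is a bound and not a measured number: the limit of > 100000 nM in this assay, at which 3 of the 4 values shown sit.

On these data alone, how much the fluoro, chloro and trifluoromethyl members differ from one another therefore stays unknown, and no order among them can be given. Also open, as far as these compounds go, is whether methoxy is alone in giving a true number here, or whether an ethoxy group, a hydroxyl or an amine at the same place would do the same.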